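Series notes: substitution on the benzyl ring of compound 1

The compounds below may be only part of what the source reports. "The series", "measured", "known", "first", "only" and "open" are said of these compounds alone.

Measured so far:
compound 1 `FC(F)(F)c1ccccc1-c1nc(NCc2ccccc2)c2ccccc2n1` — 3100 nM
compound 2 `FC(F)(F)c1ccccc1-c1nc(NCc2ccc(-c3ccc(Cl)c(Cl)c3)cc2)c2ccccc2n1` — 2200 nM

Both numbers come from an assay on a protein complex for inhibition of ubiquitin carboxyl-terminal hydrolase 1/WD repeat-containing protein 48 (Homo sapiens), read by fluorescence; on this read-out lower numbers stand for stronger inhibition and higher numbers for weaker inhibition. On these two values compound 1 stands highest; its nearest neighbour is compound 2, reached by a 1.4-fold lower number from compound 1 to compound 2 (0.15 log units; within the scatter). That single measured step puts 3,4-dichlorophenyl in place of hydrogen on an aromatic carbon and leaves the read-out within the scatter, so the two compounds cannot be ordered against each other.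

Compound 3 `FC(F)(F)c1ccccc1-c1nc(NCc2ccc(-c3cncnc3)cc2)c2ccccc2n1` is not yet measured in this assay. It differs from compound 1 by pyrimidin-5-yl in place of hydrogen on an aromatic carbon. Within the data shown here, the only measured step that bears on this place is a 1.4-fold lower number from compound 1 to compound 2 (0.15 log units; within the scatter), and it stayed within the scatter. Nothing measured separates pyrimidin-5-yl from 3,4-dichlorophenyl at this place, so in this assay the expected outcome for compound 3 is no step beyond the scatter, which as a number is expected to be a 1.1-fold lower number from compound 1 to compound 3 (0.06 log units; within the scatter). Compound 3 is accordingly estimated at 2700 nM, with a range from 900 nM to 8000 nM, the breadth reflecting that a single neighbouring step is all the series offers.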

Compound 3, half-maximal inhibitory concentration: 3000 nM
Beside the measured number, compound 3's estimate is 1.1-fold (0.05 log units) below it; measured number inside the range.
By their numbers in this assay, from the lowest: compounds 2, 3 and 1 (each within the scatter of the next).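

In this assay, a second ring of a different kind at this place, on an aromatic carbon para to a large group, gives a 1.0-fold lower number from compound 1 to compound 3 (0.01 log units; within the scatter) and, set against the dichlorinated ring, a 1.4-fold higher number from compound 2 to compound 3 (0.13 log units; within the scatter). Compound 2 alone could not show whether its small step was peculiar to 3,4-dichlorophenyl, but pyrimidin-5-yl, a six-membered aromatic ring with 2 hetero atoms and 2 hydrogen-bond acceptors, also cannot be told apart from hydrogen here. Across compounds 1, 2 and 3 the read-out therefore separates none of the three groups at this place, and no accompanying data offer an explanation for that.

Still open, as far as these compounds go, is whether a group of another kind on this aromatic carbon, such as a primary amine, a carboxylic acid or a longer alkyl chain ending in a morpholine ring, would bring a step beyond the scatter. The compounds shown also leave open whether any of these aryl groups would behave the same way at another carbon of the benzyl ring.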